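From 2-methoxyphenyl to 4-ethoxyphenyl on the shared core

The compounds below may be only part of what the source reports. "The series", "measured", "known", "first", "only" and "open" are said of these compounds alone.

In a functional assay on Jurkat cells (Homo sapiens) for antiproliferative activity, read by MTT assay, with a stated time of 72 h (on this read-out higher numbers stand for weaker inhibition and lower numbers for stronger inhibition), compound 1 (`COc1cc(C(=O)c2sc3ccccc3c2-c2ccccc2)cc(OC)c1OC`) gives 1500 nM and compound 2 (`COc1ccccc1-c1c(C(=O)c2cc(OC)c(OC)c(OC)c2)sc2ccccc12`) gives 2900 nM, so the two cannot be told apart. Among the measured compounds shown here, the single measured step, a 1.9-fold higher number from compound 1 to compound 2 (0.29 log units; within the scatter), is a methoxy in place of hydrogen and offers only a weak guide. Compound 3 (`CCOc1ccc(-c2c(C(=O)c3cc(OC)c(OC)c(OC)c3)sc3ccccc23)cc1`) carries 4-ethoxyphenyl in place of 2-methoxyphenyl on an aromatic carbon. A modest move toward stronger inhibition in this assay is expected, with wide uncertainty. The expected step is a 2.4-fold lower number from compound 2 to compound 3 (0.38 log units; beyond the scatter). Compound 3 is estimated at 1200 nM, within a range of 250 nM to 5000 nM.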

Compound 3, half-maximal inhibitory concentration: 4100 nM
For compound 3 the middle estimate is 3.4-fold (0.53 log units) below the measured one; the range from low to high includes it.
By their numbers in this assay, from the lowest: compounds 1, 2 and 3 (each within the scatter of the next, the first and the last beyond it).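

In this assay, the step from 2-methoxyphenyl to 4-ethoxyphenyl, a 1.4-fold higher number from compound 2 to compound 3 (0.15 log units; within the scatter), brings no separation, so this change on the aromatic carbon gives no gain in inhibition. Among the compounds shown here, the ethoxy in place of hydrogen, a 2.7-fold higher number from compound 1 to compound 3 (0.44 log units; beyond the scatter), is the first step at this position to clear the scatter, though it remains modest and points toward weaker inhibition. Nothing available explains this result. Compound 3 changes both the alkoxy group and its place on the phenyl ring, so the two changes cannot be separated. As far as these compounds go, how an amine or a carboxylic acid would behave on that phenyl ring remains open.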